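A few compounds are considered here, and "the series" means these few. Any claim that something is new, unique, unknown or untested is made for them only; others in the source may bear on it.

Working notes on the series. Among the measured compounds shown here, compound 3 `COc1ccc(C(=O)Nc2c(F)cccc2F)cc1OC` gives 900 nM in an assay on isolated protein for inhibition of phosphodiesterase 4A (Sus scrofa) (on this read-out higher numbers stand for weaker inhibition and lower numbers for stronger inhibition), which puts it second highest of the three numbers measured so far. Its nearest neighbour on the numbers is compound 1 `COc1ccc(C(=O)Nc2ccccc2Cl)cc1OC1CCCC1`, which in this assay gives 190 nM; the furthest is compound 2 `COc1ccc(C(=O)Nc2c(F)cccc2F)cc1`, which in this assay gives 37000 nM. For the measured compounds named here, the one single-point step measured so far is a 41-fold lower number from compound 2 to compound 3 (1.61 log units; beyond the scatter), a large move for methoxy in place of hydrogen on an aromatic carbon.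

Compound 4 `COc1ccc(C(=O)Nc2c(F)cccc2F)cc1OC1CCCCC1` is not yet measured. It differs from compound 3 by cyclohexyl in place of methyl on an oxygen on an aromatic ring. Going by the values given here, no measured step covers this exact change. What bears on it is indirect: the step from compound 2 to compound 3 shows that the alkoxy position is sensitive, and compound 1, carrying a cyclopentyloxy group on an otherwise different anilide, gives a lower number than compound 3. Compound 4 is therefore expected to show a lower number than compound 3, a step of a 6.0-fold lower number from compound 3 to compound 4 (0.78 log units; beyond the scatter) in this assay. For compound 4 the estimate in this assay is 150 nM, with a range from 40 nM to 600 nM.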

Compound 4, half-maximal inhibitory concentration: 400 nM
Compound 4: middle estimate off by 2.7-fold (0.43 log units), on the low side, and the stated range covers the measured number.
By their numbers in this assay, from the lowest: compound 1; then compound 4; then compound 3; then compound 2.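

On this oxygen on an aromatic ring, cyclohexyl is accepted in place of methyl in this assay and gives a 2.3-fold lower number from compound 3 to compound 4 (0.35 log units; beyond the scatter), so the number keeps falling with the larger group, though only modestly. Set against a 41-fold lower number from compound 2 to compound 3 (1.61 log units; beyond the scatter), the new step of a 93-fold lower number from compound 2 to compound 4 (1.97 log units; beyond the scatter) shows that most of the fall from the hydrogen compound already appears with methoxy, and cyclohexyloxy adds a smaller further part. No measurement shown gives a reason for either step.

Compound 1 differs from compound 4 in more than one place, so its cyclopentyl group cannot be separated from the rest of its anilide. Also open, on these data alone, is how a longer chain such as n-butyl, or a chain ending in an amine, would read on this oxygen.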